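Fluoropyridyl ether isomers and oral exposure in rat

The compounds below may be only part of what the source reports. "The series", "measured", "known", "first", "only" and "open" are said of these compounds alone.

Measured so far:
Compound 1 `C[C@@H](Cn1c(=O)[nH]/c(=N\c2ccc(Oc3nccs3)cc2)n(Cc2ccc(Cl)cc2)c1=O)C(=O)O`: 41.4%
Compound 2 `C[C@@H](Cn1c(=O)[nH]/c(=N\c2ccc(Oc3cncc(F)c3)cc2)n(Cc2ccc(Cl)cc2)c1=O)C(=O)O`: 74.3%
Compound 3 `C[C@@H](Cn1c(=O)[nH]/c(=N\c2ccc(Oc3cccc(F)n3)cc2)n(Cc2ccc(Cl)cc2)c1=O)C(=O)O`: 60%

All three share one core and differ only in the group on the ether oxygen, each examined in an ADME assay on the whole organism (Rattus norvegicus) for pharmacokinetics, using cassette dosing, at a dose of 1 mg/kg by the oral route; a lower number here means that a smaller share of the oral dose reaches the circulation, a higher number that a larger share of the oral dose reaches the circulation. Compound 3 stands second highest of the three numbers, with compound 2 above it and compound 1 below it; the steps into it read a number 18.6 percentage points higher from compound 1 to compound 3 (beyond the scatter) and a number 14.3 percentage points lower from compound 2 to compound 3 (beyond the scatter), both beyond the scatter. The largest step in the set is a number 32.9 percentage points higher from compound 1 to compound 2 (beyond the scatter).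

Compound 4 `C[C@@H](Cn1c(=O)[nH]/c(=N\c2ccc(Oc3ccnc(F)c3)cc2)n(Cc2ccc(Cl)cc2)c1=O)C(=O)O` differs from compound 3 by 2-fluoropyridin-4-yl in place of 6-fluoropyridin-2-yl on an oxygen on an aromatic ring. The step that bears most directly on this change is the exchange of one fluoropyridyl isomer for another, a number 14.3 percentage points lower from compound 2 to compound 3 (beyond the scatter), which was modest. The large step, a number 32.9 percentage points higher from compound 1 to compound 2 (beyond the scatter), involved a different ring altogether and is a weaker guide. A modest step at most is therefore expected, with no firm direction; the estimated step from compound 3 is a number 3 percentage points higher from compound 3 to compound 4 (within the scatter). Compound 4 is expected to give about 63% in this assay, within a range of 45% to 82%.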

Compound 4, oral bioavailability: 43.2%
The estimate for compound 4 lay 19.8 percentage points above the measured number, and the stated range ends above it.
By their numbers in this assay, from the lowest: compounds 1 and 4 (each within the scatter of the next); then compound 3; then compound 2.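

At this position, on an oxygen on an aromatic ring, exchanging one fluoropyridyl isomer for another with the same atoms is enough to move the number in this assay: there is a number 16.8 percentage points lower from compound 3 to compound 4 (beyond the scatter) and a number 31.1 percentage points lower from compound 2 to compound 4 (beyond the scatter). With a number 1.8 percentage points higher from compound 1 to compound 4 (within the scatter), 2-fluoropyridin-4-yl does not show the rise over 1,3-thiazol-2-yl seen with the other two fluoropyridyl groups, so a fluoropyridyl group as such does not secure a higher number in this set. Nothing shown accounts for the differences between these isomers.

Open, as far as these compounds go, is whether the same order among the three isomers would hold with a nitrile or a methoxy group in place of fluorine. Also open, from the compounds shown here alone, is whether it would persist if an amide replaced the carboxylic acid of the shared core.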